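Swapping the amide-side aryl group on a shared flavonol core

The source may report more compounds than this note shows. Statements on the series, on what has been measured and on what is new or still open speak of the compounds shown alone.

Measured so far:
Compound 1 `O=C(Nc1cccc(-c2oc3cc(-c4ccc(F)cc4)ccc3c(=O)c2O)c1)c1ccc(Cl)cc1` gives 3670 nM
Compound 2 `CCc1ccc(C(=O)Nc2cccc(-c3oc4cc(-c5ccc(F)cc5)ccc4c(=O)c3O)c2)cc1` gives 21000 nM
Compound 3 `Cc1cc(C(=O)Nc2cccc(-c3oc4cc(-c5ccc(F)cc5)ccc4c(=O)c3O)c2)ccc1F` gives 18900 nM

These three compounds share the same core and differ only in the aryl group attached to the carbonyl carbon of the amide. In a functional assay on HeLa cells (Homo sapiens) for antiproliferative activity, read by CCK-8 assay, with a stated time of 72 h (on this read-out higher numbers stand for weaker inhibition and lower numbers for stronger inhibition), compound 3 stands second highest of the three numbers; its nearest neighbour is compound 2, and the gap between them is within the scatter, while compound 1 sits well apart, as a 5.1-fold higher number from compound 1 to compound 3 (0.71 log units; beyond the scatter) shows.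

Compound 4 `O=C(Nc1cccc(-c2oc3cc(-c4ccc(F)cc4)ccc3c(=O)c2O)c1)c1cc(F)cc(F)c1` is the next step: 3,5-difluorophenyl in place of 4-fluoro-3-methylphenyl on a carbonyl carbon. For the measured compounds named here, no measured pair covers this exact exchange. Going by the values given here, the steps that bear on it are a 5.1-fold higher number from compound 1 to compound 3 (0.71 log units; beyond the scatter) and a 1.1-fold lower number from compound 2 to compound 3 (0.05 log units; within the scatter), which together show that changing this aryl group can move the number well beyond the scatter or leave it essentially unchanged. Only compound 1 has a single halogen on this ring, and it gives the lowest number. A move back toward that region is therefore plausible for compound 4, but the evidence is thin.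

Compound 4 is expected to give about 9000 nM, somewhere between 2500 nM and 35000 nM, which is estimated as a 2.1-fold lower number from compound 3 to compound 4 (0.32 log units; beyond the scatter).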

Compound 4, half-maximal inhibitory concentration: 3380 nM
For compound 4 the middle estimate is 2.7-fold (0.43 log units) above the measured one; the measured number falls inside the stated range.
By their numbers in this assay, from the lowest: compounds 4 and 1 (each within the scatter of the next); then compounds 3 and 2 (each within the scatter of the next).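

In this assay, putting 3,5-difluorophenyl in place of 4-fluoro-3-methylphenyl on the carbonyl carbon lowers the number well beyond the scatter (a 5.6-fold lower number from compound 3 to compound 4 (0.75 log units; beyond the scatter)), and the exchange for 4-ethylphenyl points the same way (a 6.2-fold lower number from compound 2 to compound 4 (0.79 log units; beyond the scatter)). Against 4-chlorophenyl there is no real change (a 1.1-fold lower number from compound 1 to compound 4 (0.04 log units; within the scatter)), so among these four compounds a single chlorine is not the only ring that reaches this level: the two rings bearing only halogen sit together, the two bearing an alkyl group sit together at higher numbers, and the fluorine on the ring of compound 3 does not bring it into the lower group. Nothing available here accounts for this split, so its cause remains unknown.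

The compounds shown leave open whether the alkyl group or the count of halogens matters more, since a plain phenyl ring and a ring carrying only a methyl group do not appear among them. They also do not tell how this position would respond to quite different groups, such as a methoxy, an amine or a carboxylic acid on the ring.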